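Aminobenzamide analogue of compound 1: expected antiproliferative activity

This account rests on a few compounds, and the source may have more. Where it says the series, first, only, none or still open, it means among the compounds named here.

Measured so far:
- compound 1, `CCN1CCN(c2ccc(C(=O)Nc3n[nH]c4nc(-c5c(Cl)c(OC)cc(OC)c5Cl)ccc34)cc2)CC1`: 0.7 nM
- compound 2, `COc1cc(OC)c(Cl)c(-c2ccc3c(NC(=O)c4ccc(N5CCN(C)CC5)cc4)n[nH]c3c2)c1Cl`: 324 nM

In a functional assay on NCI-H1581 cells (Homo sapiens) for antiproliferative activity, read by CCK-8 assay, with a stated time of 72 h (a lower number here means a stronger inhibitor, a higher number a weaker inhibitor), compound 1 gives 0.7 nM, the lowest of the two numbers recorded. Compound 2 gives 324 nM in this assay, a much higher number, and the gap between the two lies beyond the usual scatter. Going by the values given here, no single-change step between measured compounds is available, so the pair tells only that the two arrangements of the shared core differ strongly.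

Compound 3, `COc1cc(OC)c(Cl)c(-c2ccc3c(NC(=O)c4ccc(N)cc4)n[nH]c3n2)c1Cl`, is not yet measured. It keeps the core of compound 1 and differs from it as follows: amino in place of 4-ethylpiperazin-1-yl on an aromatic carbon. Among the compounds with values here, the group that enters is far smaller than the one that leaves, and no measured pair shows the effect of such a change. A moderate loss, beyond the scatter, is expected from compound 1 to compound 3, about a 7.1-fold higher number from compound 1 to compound 3 (0.85 log units; beyond the scatter). Compound 3 is therefore estimated at 5 nM, within 1 nM to 30 nM.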

Compound 3, half-maximal inhibitory concentration: 218 nM
The estimate for compound 3 lay 44-fold (1.64 log units) below the measured number; measured number above the stated range.
By their numbers in this assay, from the lowest: compound 1; then compounds 3 and 2 (each within the scatter of the next).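

In this assay, going by these compounds alone, amino in place of 4-ethylpiperazin-1-yl on this aromatic carbon, para to a large group, gives a 310-fold higher number from compound 1 to compound 3 (2.49 log units; beyond the scatter), the first single-place step. The position is therefore far from indifferent to this change, and the low number of compound 1 depends on keeping 4-ethylpiperazin-1-yl rather than amino here. No measured property of either group is available to account for the step.

From the compounds shown here alone, whether the loss follows from removing the six-membered non-aromatic ring or only its ethyl group remains open, and a piperazine without the ethyl, a morpholine ring or a dimethylamino group at this place would divide the step. Within the data shown here, with only two groups compared here, no trend with group size can yet be drawn.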